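From Fluoro to Chloro on the Aromatic Ring

A few compounds are considered here, and "the series" means these few. Any claim that something is new, unique, unknown or untested is made for them only; others in the source may bear on it.

Of the compounds shown here, two have been measured so far in an ADME assay on NIH3T3 cells (Mus musculus) for cytotoxicity, read by MTT assay, with a stated time of 24 h; on this read-out lower numbers stand for stronger inhibition and higher numbers for weaker inhibition. Within the data shown here, compound 1 (`O=C1OC(Cn2sccc2=O)CN1c1ccccc1`) gives 162 ug/mL, and compound 2 (`O=C1OC(Cn2sccc2=O)CN1c1ccc(F)cc1`) gives 174 ug/mL, so compound 2 stands level with its only neighbour once the usual scatter of repeat measurements is allowed for.

The next compound, compound 3 (`O=C1OC(Cn2sccc2=O)CN1c1ccc(Cl)cc1`), keeps the shared core and has chloro in place of fluoro on an aromatic carbon, para to a large group: chloro in place of fluoro on an aromatic carbon.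

Among the measured compounds shown here, only one measured step bears on this swap. It is a 1.1-fold higher number from compound 1 to compound 2 (0.03 log units; within the scatter), seen when fluoro took the place of hydrogen on an aromatic carbon. For the measured compounds named here, this single step within the scatter is thin evidence, and no compound carrying chloro has yet been tested in this assay. Even so, it offers no reason to expect a large move in either direction.

The expected result is a 1.1-fold lower number from compound 2 to compound 3 (0.02 log units; within the scatter), an estimated step that stays within the scatter. Compound 3 is estimated at 165 ug/mL, with an expected range from 95 ug/mL to 280 ug/mL.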

Compound 3, half-maximal inhibitory concentration: 194 ug/mL
For compound 3 the middle estimate is 1.2-fold (0.07 log units) below the measured one, within the range that was stated.
By their numbers in this assay, from the lowest: compounds 1, 2 and 3 (each within the scatter of the next).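

In this assay the change of fluoro to chloro on this aromatic carbon, para to a large group, gives a 1.1-fold higher number from compound 2 to compound 3 (0.05 log units; within the scatter) and so stays inside the normal noise of repeated measurements. Compared directly with the parent that carries only hydrogen at this carbon, chloro gives a 1.2-fold higher number from compound 1 to compound 3 (0.08 log units; within the scatter) and again does not separate from it, so hydrogen, fluoro and chloro all read alike here, whereas the earlier pair could show this only for hydrogen and fluoro. The data at hand offer no measurement that would explain this flat picture.

Across these three compounds the number does not respond to the group at this carbon, but that finding covers only hydrogen and two halogens at one place on the ring. On these data alone, whether an amine, a carboxylic acid or a longer chain at this same carbon would move the number beyond the scatter remains open, as does the effect of a change anywhere else on the shared core.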